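The source may report more compounds than this note shows. Statements on the series, on what has been measured and on what is new or still open speak of the compounds shown alone.

Measured so far in a functional assay on MCF7 cells (Homo sapiens) for inhibition, read by CCK-8 assay, with a stated time of 72 h; a higher number here means a weaker inhibitor, a lower number a stronger inhibitor
- compound 1 `O=C(/C=C/c1cccnc1)NCCCCCCCc1ccc(S(=O)(=O)Nc2ccccc2)cc1` gives 37.6 nM
- compound 2 `O=C(/C=C/c1cccnc1)NCCCCCCc1cccc(S(=O)(=O)Nc2ccccc2)c1` gives 0.63 nM

Compound 2 holds the lower of the two numbers (0.63 nM), a gap to compound 1 well beyond the scatter. Compound 3 (`Cc1cccc(NS(=O)(=O)c2cccc(CCCCCCNC(=O)/C=C/c3cccnc3)c2)c1`) differs from compound 2 by methyl in place of hydrogen on an aromatic carbon on the aniline side, phenyl to 3-methylphenyl: methyl in place of hydrogen on an aromatic carbon. For the measured compounds named here, no measured pair covers this kind of change, so the expectation is loose. In this assay an estimated 1.6-fold higher number from compound 2 to compound 3 (0.20 log units; within the scatter) is expected, a small rise that may stay within the scatter. For compound 3 the estimate is 1 nM (expected range 0.25 nM to 5 nM).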

Compound 3, half-maximal inhibitory concentration: 4 nM
The estimate for compound 3 lay 4.0-fold (0.60 log units) below the measured number; measured number inside the range.
By their numbers in this assay, from the lowest: compound 2; then compound 3; then compound 1.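

In this assay, the aniline side responds to a single added carbon: phenyl to 3-methylphenyl gives a 6.3-fold higher number from compound 2 to compound 3 (0.80 log units; beyond the scatter), a modest rise beyond the scatter. For the compounds shown here, this is the first step measured on that ring, so the ring is not indifferent to substitution at this carbon. Nothing measured here accounts for the rise.

Open, on these data alone, is whether the rise tracks this methyl specifically or any group at this carbon. A chlorine, methoxy or ethyl group there would separate these readings, and a single step cannot show which holds.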